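The source may report more compounds than this note shows. Statements on the series, on what has been measured and on what is new or still open speak of the compounds shown alone.

Compound 3 `COc1ccc2c(c1)C1(C(=O)N2Cc2ccccc2)C(C#N)=C(N)Oc2cc3oc(-c4ccccc4)cc(=O)c3c(O)c21` is the starting point for this step. In a functional assay on A549 cells (Homo sapiens) for antiproliferative activity, read by MTT assay, with a stated time of 48 h (on this read-out higher numbers stand for weaker inhibition and lower numbers for stronger inhibition), compound 3 gives > 50000 nM, which is a limit of the assay and not a number. Compound 2 `Cc1ccc2c(c1)C1(C(=O)N2Cc2ccccc2)C(C#N)=C(N)Oc2cc3oc(-c4ccccc4)cc(=O)c3c(O)c21` sits at the same boundary: in this assay compound 2 gives > 50000 nM, again a limit and not a number. The step that the two limits leave unreadable from compound 2 to compound 3 is therefore unreadable, since both of its ends rest on (the limit of > 50000 nM in this assay, at which 2 of the 3 values shown sit). Going by the values given here, compound 1 `CN1C(=O)C2(C(C#N)=C(N)Oc3cc4oc(-c5ccccc5)cc(=O)c4c(O)c32)c2cc(Br)ccc21` is the only member with a measured number; in this assay compound 1 gives 3150 nM, but it differs from compound 3 in more than one place, so no single step connects the two, and its value is set aside here.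

Compound 4 `N#CC1=C(N)Oc2cc3oc(-c4ccccc4)cc(=O)c3c(O)c2C12C(=O)N(Cc1ccccc1)c1ccc(F)cc12` carries the change (fluoro in place of methoxy on an aromatic carbon). Among the compounds with values here, no measured step bears directly on this change: the one step among the measured compounds, from compound 2 to compound 3, has no readable size, and the two values show only that both remain at the limit. With nothing pointing to a gain large enough to bring compound 4 inside the measurable range, the expectation is a step of no readable size. Compound 4 is accordingly expected near 45000 nM, with a range from 8000 nM to 200000 nM. The expected step of an at least 1.1-fold lower number from compound 3 to compound 4 (0.04 log units; that floor lies within the scatter) is thus none beyond the scatter, and the value is most likely to be reported again as a limit.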

Compound 4, half-maximal inhibitory concentration: > 50000 nM
Compound 4 gave a limit, no number; the forecaster's own chance of this, stated with the estimate: 65%; at least 1.1-fold (0.04 log units) between middle value and limit.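

Compound 2, compound 3 and compound 4 all sit at a limit and not at a number, so no step among them can be read: the limit of > 50000 nM in this assay, at which 3 of the 4 values shown sit.

The compounds shown leave open whether methyl, methoxy and fluoro differ at all on this aromatic carbon, and which of its several differences sets compound 1, at 3150 nM, apart.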